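A few compounds are considered here, and "the series" means these few. Any claim that something is new, unique, unknown or untested is made for them only; others in the source may bear on it.

Measured so far:
compound 1, `Cn1cc(C2=C(c3nn(CCCN4CCCCC4)c4ncccc34)C(=O)N(c3ccccn3)C2=O)c2ccccc21`: 7300 nM
compound 2, `CN(C)CCCn1nc(C2=C(c3cn(C)c4ccccc34)C(=O)N(c3ccccc3)C2=O)c2cccnc21`: 5840 nM

Both were tested in a functional assay on ECa-109 cells (Homo sapiens) for antiproliferative activity, read by MTT assay, with a stated time of 48 h; on this read-out higher numbers stand for weaker inhibition and lower numbers for stronger inhibition. Compound 1 gives 7300 nM and compound 2 gives 5840 nM. Compound 1 thus holds the higher of the two numbers, yet the gap to compound 2 lies within the scatter, so the two cannot be told apart. Compound 3, `COc1ccc(N2C(=O)C(c3cn(C)c4ccccc34)=C(c3nn(CCCN4CCCCC4)c4ncccc34)C2=O)cc1`, follows from compound 1 by a single change: 4-methoxyphenyl in place of pyridin-2-yl on an amide-type nitrogen in a ring. Among the measured compounds shown here, no measured pair isolates this change, and compound 2, which differs from compound 1 in more than one place, sits within the scatter of compound 1, so the two values give no sign of any movement to build on. The step is therefore expected to be small, within the scatter and without a firm direction, and a 1.1-fold lower number from compound 1 to compound 3 (0.05 log units; within the scatter) is what is expected. Compound 3 is estimated at 6500 nM, with a range from 2500 nM to 17000 nM.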

Compound 3, half-maximal inhibitory concentration: 3340 nM
Beside the measured number, compound 3's estimate is 1.9-fold (0.29 log units) above it, and the stated range covers the measured number.
By their numbers in this assay, from the lowest: compounds 3, 2 and 1 (each within the scatter of the next, the first and the last beyond it).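

In this assay the amide-type nitrogen in a ring gives the first readable single-place step, with 4-methoxyphenyl in place of pyridin-2-yl producing a modest move beyond the scatter (a 2.2-fold lower number from compound 1 to compound 3 (0.34 log units; beyond the scatter)). This shows that the number responds to the group at this position, which compound 1 and compound 2 could not show, as they differ in more than one place and lie within the scatter of each other. Nothing at hand accounts for the step.

The change replaces a ring holding a hetero atom with a ring of carbon only and adds the methoxy group in the same step, so the compounds shown do not separate these two parts, and compound 2, with its plain phenyl, differs in other places too. Also open, going by these compounds, is how a 4-aminophenyl or benzyl group on this nitrogen would read.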